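The source may hold more compounds than are shown below. What is called first, only, known or untested is meant among the compounds shown, and "the series" means these compounds.

Measured compounds in the series:

compound 1 `Fc1ccc(-c2nn(-c3ccccc3)cc2-c2nc3cc(F)ccc3[nH]2)cc1`: 950 nM
compound 2 `Fc1ccc(-c2nn(-c3ccccc3)cc2-c2nc3cc(Cl)ccc3[nH]2)cc1`: 2230 nM
compound 3 `COc1ccc(-c2nn(-c3ccccc3)cc2-c2nc3cc(F)ccc3[nH]2)cc1`: 1510 nM

All three numbers come from a functional assay on MCF7 cells (Homo sapiens) for antiproliferative activity, read by MTT assay, with a stated time of 48 h; a higher number here means a weaker inhibitor, a lower number a stronger inhibitor. Among the measured compounds shown here, the one change that has been measured twice is the exchange on the fused ring: going from compound 1 to compound 2, (chloro in place of fluoro on an aromatic carbon), gives a 2.3-fold higher number from compound 1 to compound 2 (0.37 log units; beyond the scatter). The other measured change, from compound 1 to compound 3, (methoxy in place of fluoro on an aromatic carbon), gives a 1.6-fold higher number from compound 1 to compound 3 (0.20 log units; within the scatter); in this assay compound 3 therefore sits in the same range as compound 1, and its number also stands within the scatter of compound 2, so no order among compounds 2 and 3 can be read from these two values.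

Compound 4 `COc1ccc(-c2nn(-c3ccccc3)cc2-c2nc3cc(Cl)ccc3[nH]2)cc1` has not yet been measured. It differs from compound 3 by chloro in place of fluoro on an aromatic carbon. The place of this change reads word for word as the place of the change from compound 1 to compound 2, so the two are the same change, applied once on the core of compound 1 and once on the core of compound 3; how the two cores differ is given above by methoxy in place of fluoro on an aromatic carbon.

For the measured compounds named here, only one pair shows this change, so the expectation rests on a single step. Going by the values given here, the step from compound 3 to compound 4 in this assay is expected to be a 2.3-fold higher number from compound 3 to compound 4 (0.35 log units; beyond the scatter), because a 2.3-fold higher number from compound 1 to compound 2 (0.37 log units; beyond the scatter) is the only measure of this exchange available. Compound 4 is expected to give about 3400 nM, with a likely range from 1700 nM to 7000 nM.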

Compound 4, half-maximal inhibitory concentration: 1760 nM
The estimate for compound 4 lay 1.9-fold (0.29 log units) above the measured number; the range from low to high includes it.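

Chloro in place of fluoro, carried to the second core, gives a 1.2-fold higher number from compound 3 to compound 4 (0.07 log units; within the scatter) in this assay, and this step cannot be told apart from its counterpart on the core of compound 1: the same change on two cores in this assay, a 2.3-fold higher number (0.37 log units; beyond the scatter) from compound 1 to compound 2 and a 1.2-fold higher number (0.07 log units; within the scatter) from compound 3 to compound 4, 2.0-fold (0.30 log units) apart, within the scatter of two such steps

The reverse view of the same square, methoxy in place of fluoro with chloro already present, gives a 1.3-fold lower number from compound 2 to compound 4 (0.10 log units; within the scatter), and here too the two cores cannot be told apart: the same change on two cores in this assay, a 1.6-fold higher number (0.20 log units; within the scatter) from compound 1 to compound 3 and a 1.3-fold lower number (0.10 log units; within the scatter) from compound 2 to compound 4, 2.0-fold (0.30 log units) apart, within the scatter of two such steps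

Among the compounds shown here, the four compounds are therefore compatible with each exchange carrying from one core to the other, but they do not show that it does: each exchange has only two readings, the chloro step is beyond the scatter on one core and within it on the other, and a real dependence on the core of a size similar to this gap can be neither confirmed nor excluded.

In these compounds, the two changed places hold only fluoro, chloro and methoxy, while the rest of the shared core stays the same. From the compounds shown here alone, how an amine, a carboxylic acid or a longer alkoxy chain at either place would read in this assay remains open, as does whether any such group would give a step large enough to stand clear of the scatter on both cores.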